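This account rests on a few compounds, and the source may have more. Where it says the series, first, only, none or still open, it means among the compounds named here.

Measured so far:
compound 1, `Clc1ccc(-c2ccc(Cn3nnc4ccccc43)cc2)c(Cl)c1`: 79 nM
compound 2, `FC(F)(F)c1cc(Br)c2nnn(CC3CC3)c2c1`: 140 nM

In a functional assay on cells for positive allosteric modulation of metabotropic glutamate receptor 2 (Homo sapiens), read by fluorescence and calcium flux, with a stated time of 30 min (a higher number here means that more compound is needed for the effect, a lower number that less compound is needed), compound 2 gives 140 nM and compound 1 gives 79 nM; the two numbers sit within the usual scatter of each other, so neither compound is set apart from the other on this read-out. The two compounds share no single-point relation, and their values are all that is known of them side by side.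

Compound 3, `COc1cc(Br)c2nnn(CC3CC3)c2c1`, differs from compound 2 in one place: methoxy in place of trifluoromethyl on an aromatic carbon. Going by the values given here, no measured pair shows this exchange, so nothing in the data fixes its effect. The expectation is that the step of a 2.9-fold higher number from compound 2 to compound 3 (0.46 log units; beyond the scatter) comes out as a moderate rise in the number, at the edge of or somewhat beyond the scatter. For compound 3 in this assay the estimate is 400 nM, with a range from 120 nM to 1500 nM.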

Compound 3, half-maximal effective concentration: 730 nM
The estimate for compound 3 lay 1.8-fold (0.26 log units) below the measured number, and the stated range covers the measured number.
By their numbers in this assay, from the lowest: compounds 1 and 2 (each within the scatter of the next); then compound 3.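

In this assay, going by these compounds alone, the aromatic carbon meta to a bromo group proves sensitive to its substituent: methoxy in place of trifluoromethyl gives a 5.2-fold higher number from compound 2 to compound 3 (0.72 log units; beyond the scatter) and thus the first single-place step, one that lies beyond the scatter. With the rest of the molecule unchanged, the lower number of this pair belongs to trifluoromethyl, so the position is not indifferent to the exchange. Nothing measured here speaks to the reason for the step.

Going by these compounds, it remains open whether the rise is specific to methoxy or would follow other replacements of trifluoromethyl at this carbon, such as a nitrile, chloro or an amine. On these data alone, it is also open whether the same exchange would carry the same weight on the core of compound 1.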